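This account rests on a few compounds, and the source may have more. Where it says the series, first, only, none or still open, it means among the compounds named here.

Within the data shown here, compound 2 `O=CNC[C@H]1CN(c2ccc(-n3cc(-c4ccccn4)cn3)c(F)c2)C(=O)O1` gives 217000 nM in a physicochemical assay for solubility, read by HPLC, with a stated time of 24 h (a higher number here means a more soluble compound, a lower number a less soluble compound), the highest of the two numbers measured so far. Among the measured compounds shown here, its nearest neighbour, compound 1 `O=C1O[C@@H](CO)CN1c1ccc(-n2cc(-c3ccccn3)cn2)c(F)c1`, gives 56400 nM in this assay, and the single measured step, a 3.8-fold higher number from compound 1 to compound 2 (0.59 log units; beyond the scatter), is a modest rise that lies beyond the scatter. Compound 3 `CONC(=O)[C@H]1CN(c2ccc(-n3cc(-c4ccccn4)cn3)c(F)c2)C(=O)O1` differs from compound 2 by methoxycarbamoyl in place of (formylamino)methyl on a saturated ring carbon. For the measured compounds named here, the one measured step concerns a different exchange at a different carbon, so it bears only loosely on this change; it shows that this part of the structure can shift the read-out by a modest amount, but it does not tell the direction here. The expected step from compound 2 to compound 3 is therefore a small one, a 1.4-fold lower number from compound 2 to compound 3 (0.16 log units; within the scatter), close to the scatter. Compound 3 is estimated at 150000 nM, with a range from 60000 nM to 400000 nM.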

Compound 3, solubility: 78100 nM
Estimate against measurement, compound 3: 1.9-fold (0.28 log units) above; low and high end bracket the measured number.
By their numbers in this assay, from the lowest: compounds 1 and 3 (each within the scatter of the next); then compound 2.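

In this assay, the exchange of (formylamino)methyl for methoxycarbamoyl on this saturated ring carbon, next to the ring oxygen, gives a 2.8-fold lower number from compound 2 to compound 3 (0.44 log units; beyond the scatter), so the position responds to a change that keeps the hydrogen-bond donor count listed for both groups. Against hydroxymethyl, methoxycarbamoyl gives a 1.4-fold higher number from compound 1 to compound 3 (0.14 log units; within the scatter), which leaves those two groups indistinguishable in this read-out. Of the three groups now compared at this position, only (formylamino)methyl stands apart, so the earlier rise is not a general result of replacing hydroxymethyl.

No measurement available explains why (formylamino)methyl stands apart. The compounds shown also leave open how an amine, a carboxylic acid or a longer chain on this ring carbon would read in this assay, and whether these steps would hold on a different core.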